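Swapping a pyridinylamino for methoxy on a shared core

A few compounds are considered here, and "the series" means these few. Any claim that something is new, unique, unknown or untested is made for them only; others in the source may bear on it.

Measured so far:
- compound 1, `NC(N)=NC(=O)c1nc(Cl)c(N2CCCC2)nc1N`: 12%
- compound 2, `NC(N)=NC(=O)c1nc(Cl)c(Nc2ccccn2)nc1N`: "not determined" (no result reported)

Compound 1 carries a pyrrolidine on the shared core, and in an assay for inhibition of acid-sensing ion channel 3 (Homo sapiens), read by patch clamp, tested at 1 uM (on this read-out higher numbers stand for more inhibition at the one concentration tested (going by the name of the read-out) and lower numbers for less inhibition), compound 1 gives 12%, which is a modest effect at this concentration. Compound 2 keeps the same core but carries a (pyridin-2-yl)amino group in its place. In this assay compound 2 gives "not determined" (no result reported); no single number exists for it, so nothing can be said about how it compares with compound 1.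

Compound 3, `COc1nc(N)c(C(=O)N=C(N)N)nc1Cl`, is the next step. The change from compound 2 to compound 3 is methoxy in place of (pyridin-2-yl)amino on an aromatic carbon.

With no number for compound 2, the size and direction of this step in this assay cannot be given; the estimate for compound 3 stands alone. It rests on compound 1, a close relative with a small ring at the same position, because compound 1 gives 12%. Compound 3 is expected to show weak inhibition, around 15%, most likely between 0% and 40%.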

Compound 3, a percentage reported as inhibition, at one concentration (the size of the read-out at that concentration, not a potency): 21%
Compound 3: middle estimate off by 6 percentage points, on the low side, and the stated range covers the measured number.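

In this assay, putting methoxy in place of pyrrolidin-1-yl on an aromatic carbon gives a number 9 percentage points higher from compound 1 to compound 3 (within the scatter), so this one change does not separate the two compounds, even though methoxy carries no ring and pyrrolidin-1-yl does. Going by these compounds alone, this is the first comparison at this position that can be read, and within this pair the read-out does not depend on whether the attached group holds a ring. The step from compound 2 to compound 3 cannot be read, since compound 2 has no number, and nothing shown here offers an explanation for the result.

On these data alone, the effect of (pyridin-2-yl)amino at this position therefore stays unknown, as does the question of whether any group placed here can move the read-out beyond the usual scatter. It also remains open how a carboxylic acid, a longer chain such as butoxy, or a larger ring such as piperidine on the same aromatic carbon would behave, and a reading at a single concentration gives no potency for any of these compounds.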